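This account rests on a few compounds, and the source may have more. Where it says the series, first, only, none or still open, it means among the compounds named here.

Measured compounds:
- compound 1, `COc1cccc(-c2nn(-c3ccccc3)cc2-c2ccnc(NCCCNC(=O)c3cccc(C(F)(F)F)c3)c2)c1`, 3330 nM 
- compound 2, `COc1cccc(-c2nn(-c3ccccc3)cc2-c2ccnc(NCCNC(=O)Nc3cccc(C(F)(F)F)c3)c2)c1`, 1880 nM 
- compound 3, `O=C(NCCCNc1cc(-c2cn(-c3ccccc3)nc2-c2cccc(O)c2)ccn1)c1ccccc1`, 1710 nM 

In a functional assay on COLO 205 cells (Homo sapiens) for antiproliferative activity (on this read-out lower numbers stand for stronger inhibition of growth and higher numbers for weaker inhibition of growth), compound 3 gives 1710 nM. Its number sits within the usual scatter of the number of compound 2 and also within the scatter of the number of compound 1, so the three measured compounds cannot be told apart on this read-out; none of them can be called the stronger or the weaker inhibitor. No pair of these compounds differs in only one place, so no single step between measured compounds is available.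

Compound 4, `O=C(NCCCNc1cc(-c2cn(-c3ccccc3)nc2-c2cccc(O)c2)ccn1)c1ccc(F)cc1`, differs from compound 3 by one change: fluoro in place of hydrogen on an aromatic carbon. Among the compounds with values here, with no measured step of this kind among the three compounds, and with the three numbers all close to each other, the expectation is conservative. The step of a 1.1-fold lower number from compound 3 to compound 4 (0.06 log units; within the scatter) is expected to stay within the scatter, with no clear direction. Compound 4 is therefore estimated at 1500 nM, with a range from 600 nM to 4000 nM.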

Compound 4, concentration for 50% growth inhibition: 1600 nM
Compound 4: the middle estimate sits 1.1-fold (0.03 log units) below what was measured; the range from low to high includes it.
By their numbers in this assay, from the lowest: compounds 4, 3, 2 and 1 (each within the scatter of the next, the first and the last beyond it).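

In this assay, fluoro in place of hydrogen on the benzoyl group, para to a large group, gives a 1.1-fold lower number from compound 3 to compound 4 (0.03 log units; within the scatter), which lies within the scatter. Within the data shown here, this is the first step that changes only one place, and it shows that this position takes a single fluoro without a readable change in growth inhibition. No measurement shown offers an explanation for the size of this step.

Going by these compounds, a single small atom says little about the position as a whole, so it remains open whether a larger or charged group there, such as a trifluoromethyl, a nitrile, an amine or a carboxylic acid, would also leave the number within the scatter. The compounds shown also leave open how fluoro would behave elsewhere on the same ring.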